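Swapping the aryl group on the ring nitrogen

The compounds below may be only part of what the source reports. "The series", "measured", "known", "first", "only" and "open" are said of these compounds alone.

Values so far in a physicochemical assay for solubility, read by turbidimetry, measured as kinetic solubility, at pH 6.8 (a higher number here means a more soluble compound, a lower number a less soluble compound), for two compounds
- compound 1 `COc1ccc(F)cc1N1C(=O)CSC1c1cccc(C(=O)NCCCCn2cccn2)c1` gives 50000 nM
- compound 2 `COc1ccc(F)cc1N1C(=O)CSC1c1cccc(C(=O)NCCCCc2ccccc2)c1` gives 10000 nM

Among the compounds with values here, compound 1 stands higher of the two, and the only measured step (a 5.0-fold lower number from compound 1 to compound 2 (0.70 log units; beyond the scatter)) puts phenyl in place of 1H-pyrazol-1-yl on the chain. Compound 3 `O=C(NCCCCn1cccn1)c1cccc(C2SCC(=O)N2c2ccccn2)c1` keeps that chain and changes another place (pyridin-2-yl in place of 5-fluoro-2-methoxyphenyl on an amide-type nitrogen in a ring), with pyridin-2-yl in place of 5-fluoro-2-methoxyphenyl on an amide-type nitrogen in a ring. Within the data shown here, no measured step touches this place, so the one step available offers only a rough size. In that step a ring of carbon only came in and the number fell. Here such a ring leaves, so a modest rise in this assay is expected, held with little certainty. The expected change is small (a 1.4-fold higher number from compound 1 to compound 3 (0.15 log units; within the scatter)). Compound 3 is estimated at 70000 nM in an expected range from 25000 nM to 180000 nM as the likely outcome.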

Compound 3, solubility: 50000 nM
For compound 3 the middle estimate is 1.4-fold (0.15 log units) above the measured one; the measured number falls inside the stated range.
By their numbers in this assay, from the lowest: compound 2; then compounds 1 and 3 (each within the scatter of the next).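

Placing pyridin-2-yl on the amide-type nitrogen in a ring, where 5-fluoro-2-methoxyphenyl stood, gives no change at the digits printed from compound 1 to compound 3 (within the scatter) in this assay. So at this position, a six-membered aromatic ring with 1 hetero atom and 6 heavy atoms can take the place of a carbon-only ring with 9 heavy atoms and leave the number unchanged, whereas the chain change gave a 5.0-fold lower number from compound 1 to compound 2 (0.70 log units; beyond the scatter) and lay beyond the scatter. Nothing available explains why this swap leaves the reading flat.

The compounds shown leave open whether the same holds for an unsubstituted phenyl or for a pyridine ring joined through a different ring carbon. They also leave open how an amine or a carboxylic acid on this ring would read, and whether pyridin-2-yl behaves alike with the phenyl-ended chain of compound 2.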